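A few compounds are considered here, and "the series" means these few. Any claim that something is new, unique, unknown or untested is made for them only; others in the source may bear on it.

For the measured compounds named here, compound 3 `Cc1cc(-c2ccccc2)n(/C(N)=N/S(=O)(=O)c2cc(C)c(Cl)cc2SCc2cccc(C(F)(F)F)c2)n1` gives 19000 nM in a functional assay on HCT-116 cells (Homo sapiens) for cytotoxicity, read by MTT assay, with a stated time of 72 h (on this read-out higher numbers stand for weaker inhibition and lower numbers for stronger inhibition), the highest of the three numbers measured so far; compound 1 `Cc1cccc(CSc2cc(Cl)c(C)cc2S(=O)(=O)/N=C(\N)n2nccc2-c2ccccc2)c1` gives 6500 nM and compound 2 `Cc1cc(S(=O)(=O)/N=C(\N)n2nccc2-c2ccccc2)c(SCc2cccc(Cl)c2)cc1Cl` gives 7000 nM in this assay. Compound 4 `Cc1cc(-c2ccccc2)n(/C(N)=N/S(=O)(=O)c2cc(C)c(Cl)cc2SCc2ccccc2)n1` differs from compound 3 by hydrogen in place of trifluoromethyl on an aromatic carbon. Going by the values given here, the one measured step on the same benzyl ring, a 1.1-fold higher number from compound 1 to compound 2 (0.03 log units; within the scatter), shows that exchanging one substituent there for another left the number essentially unchanged. Among the compounds with values here, compounds 1 and 2, which carry other groups on that ring, sit lower than compound 3, but they also differ from it in the shared core, so no single step covers that comparison. A modest move toward a lower number is therefore expected, a 1.7-fold lower number from compound 3 to compound 4 (0.24 log units; within the scatter), and compound 4 is estimated at 11000 nM, within 4500 nM to 27000 nM.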

Compound 4, half-maximal inhibitory concentration: 10000 nM
Beside the measured number, compound 4's estimate is 1.1-fold (0.04 log units) above it, within the range that was stated.
By their numbers in this assay, from the lowest: compounds 1, 2, 4 and 3 (each within the scatter of the next, the first and the last beyond it).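

In this assay, hydrogen in place of trifluoromethyl on the benzyl ring gives a 1.9-fold lower number from compound 3 to compound 4 (0.28 log units; within the scatter) and so leaves compound 4 and compound 3 within the scatter of each other. This step sets a substituent on that ring against hydrogen itself, on the shared core of compound 3, and on this read-out the two cannot be told apart. No measurement given here bears on this result. Still open, going by these compounds, is whether a methoxy group or an amine at this place on that core would give a number apart from those of compound 3 and compound 4.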